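The source may report more compounds than this note shows. Statements on the series, on what has been measured and on what is new or still open speak of the compounds shown alone.

Compound 1 `CCC(C)/N=C(\C)c1c(O)c2ccccc2[nH]c1=O`: >= 100000 nM
Compound 2 `CCC/N=C(\C)c1c(O)c2ccccc2[nH]c1=O`: >= 100000 nM
Compound 3 `C/C(=N\CC(C)C)c1c(O)c2ccccc2[nH]c1=O`: >= 100000 nM

In an assay on isolated protein for inhibition of myosin-2 (Bos taurus), read by spectrophotometry, with a stated time of 24 min (on this read-out lower numbers stand for stronger inhibition and higher numbers for weaker inhibition), compound 3 gives >= 100000 nM, which is a limit of the assay and not a number. Compound 1 likewise reaches only a limit, >= 100000 nM. Compound 2 also stops at a limit, >= 100000 nM. All three values sit at the limit of >= 100000 nM in this assay, at which 3 of the 3 values shown sit, so none of the three compounds can be placed relative to the others. The steps between them, a step that the two limits leave unreadable from compound 1 to compound 2, a step that the two limits leave unreadable from compound 1 to compound 3 and a step that the two limits leave unreadable from compound 2 to compound 3, are therefore unreadable in size and in direction.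

Compound 4 `CCCCC/N=C(\C)c1c(O)c2ccccc2[nH]c1=O` differs from compound 3 by butyl in place of isopropyl on a saturated chain carbon bound to a double-bonded nitrogen. Within the data shown here, two measured steps touch the same region of the molecule: the change of the group on the double-bonded nitrogen from compound 1 to compound 3, and the lengthening of the chain from compound 2 to compound 3. Both were left unreadable by the limits, so they give no measure of how much a change at this chain alters potency in this assay. With three compounds at the same limit and no readable step, compound 4 is expected to show no step beyond the scatter, a number no higher from compound 3 to compound 4 (the limit leaves the size open), and is estimated at 100000 nM, within 50000 nM to 300000 nM, most likely again only as a limit.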

Compound 4, half-maximal inhibitory concentration: >= 100000 nM
Compound 4 ended at the assay's limit; the forecaster's own chance of this, stated with the estimate: 85%; the middle value sits exactly at the limit.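

In this assay compound 4 gives >= 100000 nM, a limit of the assay and not a number. Among these compounds, no step from compound 4 to compound 1, compound 2 or compound 3 can be read, in size or in direction: the limit of >= 100000 nM in this assay, at which 4 of the 4 values shown sit. The compounds shown leave open whether any group on the double-bonded nitrogen of the shared core gives a readable number in this assay.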